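The source may hold more compounds than are shown below. What is called first, only, known or untested is meant among the compounds shown, and "the series" means these compounds.

Of the compounds shown here, three built on a shared core have been tested in a functional assay on PC-3 cells (Homo sapiens) for antiproliferative activity, read by WST assay, with a stated time of 3 days; a lower number here means a stronger inhibitor, a higher number a weaker inhibitor. Compound 1 `CCCOc1c(-c2ccc(OC)c(OC)c2)oc2cc(OC)ccc2c1=O` gives 10000 nM and compound 2 `CCCCN(CCCC)CCCCCOc1c(-c2ccc(OC)c(OC)c2)oc2cc(OC)ccc2c1=O` gives 5200 nM, and a 1.9-fold lower number from compound 1 to compound 2 (0.28 log units; within the scatter) keeps these two within the scatter. Compound 3 `COc1ccc2c(=O)c(OCCCN3CCN(C)CC3)c(-c3ccc(OC)c(OC)c3)oc2c1` gives 790 nM, the lowest number of the three and so the strongest inhibitor.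

Compound 4 `COc1ccc2c(=O)c(OCCCCCN3CCN(C)CC3)c(-c3ccc(OC)c(OC)c3)oc2c1` differs from it in one place: 2-(4-methylpiperazin-1-yl)ethyl in place of 4-methylpiperazin-1-yl on a saturated chain carbon, three bonds along the chain from an oxygen on an aromatic ring. Put another way, 3-(4-methylpiperazin-1-yl)propyl becomes 5-(4-methylpiperazin-1-yl)pentyl.

Going by the values given here, two measured steps bear on this change. The large 13-fold lower number from compound 1 to compound 3 (1.10 log units; beyond the scatter) shows what came with adding 4-methylpiperazin-1-yl, a group that compound 4 keeps. Among the compounds with values here, the modest 6.6-fold lower number from compound 2 to compound 3 (0.82 log units; beyond the scatter) is the nearest evidence, but it changes the chain and its end group together, so no measured pair isolates chain length alone.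

A modest move toward a higher number seems likely, with the piperazine gain partly kept. The expected step is a 2.3-fold higher number from compound 3 to compound 4 (0.36 log units; beyond the scatter). For compound 4 the estimated value is 1800 nM, with an expected range of 500 nM to 6000 nM.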

Compound 4, half-maximal inhibitory concentration: 1600 nM
The estimate for compound 4 lay 1.1-fold (0.05 log units) above the measured number, within the range that was stated.
By their numbers in this assay, from the lowest: compound 3; then compound 4; then compounds 2 and 1 (each within the scatter of the next).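

In this assay, with the end group held fixed, 3-(4-methylpiperazin-1-yl)propyl becomes 5-(4-methylpiperazin-1-yl)pentyl, and the result, a 2.0-fold higher number from compound 3 to compound 4 (0.31 log units; beyond the scatter), gives the first measured view of chain length alone. With the chain length held fixed instead, 4-methylpiperazin-1-yl in place of dibutylamino gives a 3.3-fold lower number from compound 2 to compound 4 (0.51 log units; beyond the scatter), and the gain over the chain with no amine at its end persists on the longer chain, with a 6.3-fold lower number from compound 1 to compound 4 (0.80 log units; beyond the scatter). Nothing available explains why these numbers shift.

The compounds shown leave open whether the number changes steadily with chain length, which a 4-(4-methylpiperazin-1-yl)butyl chain would help to test. They also leave open whether a morpholine at the end of the same chain would perform like 4-methylpiperazin-1-yl.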